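Swapping Phenyl for Pyridin-2-yl on Compound 2

The source may hold more compounds than are shown below. What is called first, only, known or untested is meant among the compounds shown, and "the series" means these compounds.

In an ADME assay on L6 cells (Rattus norvegicus) for cytotoxicity (on this read-out lower numbers stand for stronger inhibition and higher numbers for weaker inhibition), compound 1 (`O=[N+]([O-])c1ccc2[nH]nc(OCc3ccccc3Cl)c2c1`) gives 30500 nM and compound 2 (`O=c1c2cc([N+](=O)[O-])ccc2[nH]n1Cc1ccccc1`) gives 234000 nM as the higher of the two numbers, a gap beyond the scatter that marks compound 2 as the weaker inhibitor. Compound 3 (`O=c1c2cc([N+](=O)[O-])ccc2[nH]n1Cc1ccccn1`) differs from compound 2 by pyridin-2-yl in place of phenyl on a saturated chain carbon bound to an aromatic nitrogen in one place: pyridin-2-yl in place of phenyl on a saturated chain carbon bound to an aromatic nitrogen. Within the data shown here, no measured pair shows this swap, so no shift beyond the scatter is expected. The expected move is a 1.2-fold lower number from compound 2 to compound 3 (0.07 log units; within the scatter) and would stay within that scatter. The estimate for compound 3 is 200000 nM (range 70000 nM to 450000 nM).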

Compound 3, half-maximal inhibitory concentration: 287000 nM
For compound 3 the middle estimate is 1.4-fold (0.16 log units) below the measured one; low and high end bracket the measured number.
By their numbers in this assay, from the lowest: compound 1; then compounds 2 and 3 (each within the scatter of the next).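

In this assay, replacing phenyl with pyridin-2-yl on a saturated chain carbon bound to an aromatic nitrogen gives a 1.2-fold higher number from compound 2 to compound 3 (0.09 log units; within the scatter) and so the two compounds cannot be told apart. At this position, then, a ring nitrogen and its added hydrogen-bond acceptor leave the read-out within the usual scatter. No supporting data are available to explain why the two compounds read alike. From the compounds shown here alone, it remains open whether pyridin-3-yl, an amine on the ring or a longer chain would shift the number beyond the scatter.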